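A few compounds are considered here, and "the series" means these few. Any claim that something is new, unique, unknown or untested is made for them only; others in the source may bear on it.

Measured compounds:
- compound 1, `O=c1[nH]c2ccccc2cc1/C=N/Cc1ccccc1`: 329000 nM
- compound 2, `Cc1ccc2[nH]c(=O)c(/C=N/c3ccccc3O)cc2c1`: 286000 nM
- compound 3, `Cc1ccc2[nH]c(=O)c(/C=N/N)cc2c1`: 153000 nM

All three numbers come from a functional assay, read by spectrophotometry, with a stated time of 5 min; a higher number here means a weaker inhibitor, a lower number a stronger inhibitor; every compound here is a weak inhibitor. Compound 3 has the lowest number of the three, but its gap to compound 2 is within the scatter, so no order between these two can be claimed. The gap from compound 3 to compound 1 is beyond the scatter.

The next compound is compound 4, `Cc1ccc2[nH]c(=O)c(/C=N/Cc3ccccc3)cc2c1`. It differs from compound 3 in one place: benzyl in place of amino on a double-bonded nitrogen.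

Among the compounds with values here, only one measured step touches the same position, a 1.9-fold lower number from compound 2 to compound 3 (0.27 log units; within the scatter), and that exchange left the number essentially where it was. Compound 1 carries the same benzyl on the double-bonded nitrogen as compound 4 and lacks only the methyl on the shared core; in this assay compound 1 gives 329000 nM, a number close to those of compound 2 and compound 3. Exchanges at this position have so far moved the number little, so the expected step from compound 3 to compound 4 is a 2.0-fold higher number from compound 3 to compound 4 (0.29 log units; within the scatter), at most a small rise and possibly nothing beyond the scatter.

Compound 4 is therefore estimated at 300000 nM in this assay, with a range from 150000 nM to 600000 nM.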

Compound 4, half-maximal inhibitory concentration: 310000 nM
Beside the measured number, compound 4's estimate is 1.0-fold (0.01 log units) below it; low and high end bracket the measured number.
By their numbers in this assay, from the lowest: compounds 3, 2, 4 and 1 (each within the scatter of the next, the first and the last beyond it).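

In this assay, within the data shown here, benzyl in place of amino on the double-bonded nitrogen gives the first step at this position that lies beyond the scatter, a 2.0-fold higher number from compound 3 to compound 4 (0.31 log units; beyond the scatter), although the step is only modest. Benzyl and 2-hydroxyphenyl cannot be ordered, a 1.1-fold higher number from compound 2 to compound 4 (0.03 log units; within the scatter), so the amino compound separates from the benzyl compound but not from the 2-hydroxyphenyl compound, and the two compounds carrying a six-membered aromatic ring on this nitrogen do not separate from each other. With benzyl held fixed, methyl in place of hydrogen on an aromatic carbon of the shared core also gives no order, a 1.1-fold lower number from compound 1 to compound 4 (0.03 log units; within the scatter), and no supporting data bear on any of these steps.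

From the compounds shown here alone, compound 3, at 153000 nM, is still a weak inhibitor, and it remains open whether a carboxylic acid, a morpholine or a longer alkyl chain on the double-bonded nitrogen would shift the number further than any group seen so far. Going by these compounds, the methyl comparison rests on a single pair carrying benzyl, so whether it holds with amino or 2-hydroxyphenyl on that nitrogen also stays open.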